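The source may report more compounds than this note shows. Statements on the series, on what has been measured and on what is new or still open speak of the compounds shown alone.

Measured so far:
compound 1 `COc1cc(-c2nn(-c3cccc(NC(=O)c4ccc(Cl)c(C(F)(F)F)c4)c3)cc2-c2ccncc2)ccc1Cl`: > 32500 nM
compound 2 `O=C(Nc1cccc(-n2cc(-c3ccncc3)c(-c3ccc(Cl)c(O)c3)n2)c1)Nc1ccc(Cl)c(C(F)(F)F)c1`: 1440 nM

Compound 1 sits at the limit of > 32500 nM in this assay, at which 1 of the 2 values shown sits. For compound 1 the figure > 32500 nM in a functional assay on MDA-MB-231 cells (Homo sapiens) for inhibition, read by sulforhodamine B assay, with a stated time of 48 h (on this read-out lower numbers stand for stronger inhibition of growth and higher numbers for weaker inhibition of growth), is a limit of the assay and not a number. Compound 2 in this assay gives 1440 nM, a measured value. For the measured compounds named here, compound 1 and compound 2 differ in more than one place, so no single step between them is computed; the two values only show that one compound is resolved by this assay and the other is not.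

Compound 3 `COc1cc(-c2nn(-c3cccc(NC(=O)Nc4ccc(Cl)c(Cl)c4)c3)cc2-c2ccncc2)ccc1Cl` is not yet measured. It differs from compound 1 by (3,4-dichlorophenyl)amino in place of 4-chloro-3-(trifluoromethyl)phenyl on a carbonyl carbon. The change from compound 1 to compound 3 is expected to move toward stronger inhibition of growth, by about an at least 10-fold lower number from compound 1 to compound 3 (1.03 log units; beyond the scatter), which would be beyond the usual scatter. Compound 3 is accordingly expected to give 3000 nM, within a range from 700 nM to 15000 nM.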

Compound 3, concentration for total growth inhibition: 1920 nM
For compound 3 the middle estimate is 1.6-fold (0.19 log units) above the measured one, within the range that was stated.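

On a carbonyl carbon whose other neighbours are an amide-type nitrogen, (3,4-dichlorophenyl)amino in place of 4-chloro-3-(trifluoromethyl)phenyl gives, in this assay, an at least 16-fold lower number from compound 1 to compound 3 (1.22 log units; beyond the scatter). This single-place step shows that the group on this carbonyl carbon can decide whether the core of compound 1 gives a resolved value at all. Compound 1 stands at a limit and not a number, so the step has no upper end: the limit of > 32500 nM in this assay, at which 1 of the 3 values shown sits.

The change brings in the amino nitrogen and alters the ring substituents together, and the compounds shown do not separate these two parts of the step. Also open, on these data alone, is how a methylene group in place of that nitrogen, or a morpholine on the carbonyl carbon, would read in this assay.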